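Swapping Cyano for Trifluoromethyl on a Selenium Chain

The compounds below may be only part of what the source reports. "The series", "measured", "known", "first", "only" and "open" are said of these compounds alone.

Three compounds have been measured in a functional assay on BGC-823 cells (Homo sapiens) for cytotoxicity, read by MTT assay, with a stated time of 72 h; on this read-out higher numbers stand for weaker inhibition and lower numbers for stronger inhibition:

compound 1, `Cc1cccc(Nc2ccccc2C(C)C(=O)OCCC[Se]C#N)c1C`, gives 22100 nM
compound 2, `Cc1cccc(Nc2ccccc2C(C)C(=O)OCCC[Se]C(F)(F)F)c1C`, gives 19600 nM
compound 3, `CC1=C(CC(=O)OCCC[Se]C#N)c2cc(F)ccc2/C1=C\c1ccc([S+](C)[O-])cc1`, gives 17500 nM

Compound 1 and compound 2 share a core and differ in one group: trifluoromethyl in place of cyano on a selenium. In this assay this change made a 1.1-fold lower number from compound 1 to compound 2 (0.05 log units; within the scatter), so the two values are, for practical purposes, the same.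

Compound 3 carries a different core; how its core differs from that of compound 1 is not broken down here. Its value sits close to those of compound 1 and compound 2, all three within the usual scatter of one another.

Compound 4, `CC1=C(CC(=O)OCCC[Se]C(F)(F)F)c2cc(F)ccc2/C1=C\c1ccc([S+](C)[O-])cc1`, is not yet measured. It differs from compound 3 in exactly the way compound 2 differs from compound 1: trifluoromethyl in place of cyano on a selenium. The surroundings of the change are the same in both pairs, so this is the same change made on another core.

Among the compounds with values here, the expectation for compound 4 in this assay is a step of about a 1.1-fold lower number from compound 3 to compound 4 (0.04 log units; within the scatter), resting on the only earlier example of this change, which gave a 1.1-fold lower number from compound 1 to compound 2 (0.05 log units; within the scatter). Compound 4 is therefore estimated at 16000 nM, expected to fall between 8000 nM and 32000 nM.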

Compound 4, half-maximal inhibitory concentration: 14400 nM
Beside the measured number, compound 4's estimate is 1.1-fold (0.05 log units) above it; measured number inside the range.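

In this assay, putting trifluoromethyl in place of cyano on a selenium gave a 1.2-fold lower number from compound 3 to compound 4 (0.08 log units; within the scatter), so on this second core the swap again leaves the number effectively unchanged. Set side by side, the two examples agree: the same change on two cores in this assay, a 1.1-fold lower number (0.05 log units; within the scatter) from compound 1 to compound 2 and a 1.2-fold lower number (0.08 log units; within the scatter) from compound 3 to compound 4, 1.1-fold (0.03 log units) apart, within the scatter of two such steps. This shows that the swap had no effect larger than the scatter on either core, but it does not show that a step of real size would carry over from one core to another, and it says nothing about cores other than these two.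

The compounds shown leave open what other groups on the selenium, such as a methyl or a phenyl, would do to the number. They also leave open whether a longer chain carrying the selenium would change it, and whether trifluoromethyl and cyano would still match each other on such a chain.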